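Two Measured Doses, One Unmeasured Chain Swap

The compounds below may be only part of what the source reports. "The series", "measured", "known", "first", "only" and "open" are said of these compounds alone.

Measured so far:
Compound 1, `Nc1nc2ccc(OCC(F)(F)C(F)(F)F)cc2s1`, gives 7.5 mg/kg in a functional assay on the whole organism with Rattus norvegicus as the target; a higher number here means that more compound is needed for the effect, a lower number that less compound is needed.
Compound 2, `CCN(CC)C(=O)Cn1c(=N)sc2cc(OC(F)(F)F)ccc21`, gives 9 mg/kg in this assay.

Compound 2 carries the higher of the two numbers, but its gap to compound 1 is within the usual scatter, so the two doses cannot be told apart and neither compound can be called the more or less potent one. The shared core of compound 2 and compound 3 is the same, and compound 3, `N=c1sc2cc(OC(F)(F)F)ccc2n1CCSc1ccccc1`, has not yet been measured in this assay. The change from compound 2 to compound 3 is (phenylsulfanyl)methyl in place of diethylcarbamoyl on a saturated chain carbon bound to an aromatic nitrogen. The group that leaves carries an amide carbonyl; the group that enters carries a phenyl ring joined through a sulfur. Within the data shown here, no measured pair in this set shows what such a swap does to the dose, so nothing here supports expecting a shift larger than the scatter in either direction. Compound 3 is therefore expected to land near compound 2, with a step of no change at the digits printed from compound 2 to compound 3 (within the scatter), and its dose is estimated at 9 mg/kg, within a range from 3 mg/kg to 27 mg/kg.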

Compound 3, dose for half-maximal effect: 4.5 mg/kg
The estimate for compound 3 lay 2.0-fold (0.30 log units) above the measured number, within the range that was stated.
By their numbers in this assay, from the lowest: compounds 3, 1 and 2 (each within the scatter of the next).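

In this assay, placing (phenylsulfanyl)methyl in place of diethylcarbamoyl on a saturated chain carbon bound to an aromatic nitrogen gives a 2.0-fold lower number from compound 2 to compound 3 (0.30 log units; within the scatter) and so does not separate the two groups. Compound 2 on its own could not show whether the amide carbonyl had to be present for a dose of this size, and this pair shows that a group without it, carrying a phenyl ring joined through a sulfur, gives a dose that cannot be told apart from that of compound 2. Nothing measured here explains how the two groups compare in the whole animal.

The swap removes the amide and brings in the sulfur and the phenyl ring all at once, so this single pair cannot say whether any one of these parts matters on its own. A benzyl group without the sulfur, a phenoxymethyl group with an oxygen in place of the sulfur, or a longer chain ending in an amine or a carboxylic acid would each ask a question that the compounds shown leave open.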